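Two methoxyphenyl arms on an allyl-bearing core

The source may report more compounds than this note shows. Statements on the series, on what has been measured and on what is new or still open speak of the compounds shown alone.

Compound 1, `COc1ccccc1/C=c1/[nH]c(=O)/c(=C\c2ccccc2OC)n(C)c1=O`, in a functional assay on Huh-7 cells (Homo sapiens) for cytotoxicity, read by CCK-8 assay, with a stated time of 72 h; on this read-out lower numbers stand for stronger inhibition and higher numbers for weaker inhibition: "not active" (no number reported)
Compound 2, `C=CCn1c(=O)/c(=C\c2cccc(F)c2)[nH]c(=O)/c1=C\c1ccccc1OC`, in this assay: 27200 nM
Compound 3, `C=CCn1c(=O)/c(=C\c2cc(Br)ccc2F)[nH]c(=O)/c1=C\c1ccccc1OC`, in this assay: "not active" (no number reported)

Compound 3 stands without a number: in this assay compound 3 is reported as "not active" (no number reported), and compound 1 is reported in the same way. Only compound 2 carries a value, and that value is weak. Compound 4, `C=CCn1c(=O)/c(=C\c2ccccc2OC)[nH]c(=O)/c1=C\c1ccccc1OC`, has not been measured. It differs from compound 3 by 2-methoxyphenyl in place of 5-bromo-2-fluorophenyl on a double-bonded chain carbon bound to an aromatic carbon. For the measured compounds named here, compound 1 shares the 2-methoxyphenyl groups of compound 4, and compound 1 gave no number in this assay, so there is no measured step from which a direction or size can be read. The expectation for compound 4 rests on the weak value of compound 2 and the missing numbers of compound 1 and compound 3: a weak result, with a real chance that no number is returned at all. Compound 4 is estimated at 45000 nM, within 15000 nM to 150000 nM.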

Compound 4, half-maximal inhibitory concentration: 21200 nM
For compound 4 the middle estimate is 2.1-fold (0.33 log units) above the measured one, within the range that was stated.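

At the place on a double-bonded chain carbon bound to an aromatic carbon, 2-methoxyphenyl and 3-fluorophenyl give values that cannot be told apart in this assay: the change is a 1.3-fold lower number from compound 2 to compound 4 (0.11 log units; within the scatter), so the 2-methoxyphenyl group carries no measurable gain or loss here. Compound 4 returns a number, whereas compound 3, with 5-bromo-2-fluorophenyl at the same place, is reported as "not active" (no number reported), and the steps that involve compound 3 or compound 1 cannot be read. No measurement at hand bears on why these results fall as they do.

The compounds shown leave open whether a carboxylic acid or a simple amine carried on that phenyl ring would return a stronger value. They also leave open how a longer chain, such as n-butyl, would behave in place of the allyl group.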